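Indole substituent swap in a weak antagonist series

This account rests on a few compounds, and the source may have more. Where it says the series, first, only, none or still open, it means among the compounds named here.

Measured in an assay on RPMI-8226 cells for antagonist activity at P2X purinoceptor 7 (Homo sapiens), read by calcium flux; a higher number here means a weaker inhibitor, a lower number a stronger inhibitor:
compound 1, `O=c1[nH]c2ccccc2n1CCCCCN1CCN(C(c2ccccc2)c2ccccc2)CC1`, gives 560 nM.
compound 2, `Cc1nc2ccccc2n1CCCCN1CCN(C(c2ccccc2)c2ccccc2)CC1`, gives 850 nM.
compound 3, `COc1ccc2c(ccn2CCCCN2CCN(C(c3ccccc3)c3ccccc3)CC2)c1`, gives only a limit of the assay, > 10000 nM.

Compound 3 therefore stands at the weak end of these three: there is an at least 17-fold higher number from compound 1 to compound 3 (1.25 log units; beyond the scatter) and an at least 11-fold higher number from compound 2 to compound 3 (1.07 log units; beyond the scatter), whereas a 1.5-fold higher number from compound 1 to compound 2 (0.18 log units; within the scatter) is small. Compound 4, `Fc1cccc2c1ccn2CCCCN1CCN(C(c2ccccc2)c2ccccc2)CC1`, differs from compound 3 by 4-fluoro-1H-indol-1-yl in place of 5-methoxy-1H-indol-1-yl on a saturated chain carbon, four bonds along the chain from an amine nitrogen in a ring. Among the measured compounds shown here, no measured step exchanges one indole substituent for another, so the expectation rests on the indole member already sitting at the limit of > 10000 nM in this assay, at which 1 of the 3 values shown sits. The step of a number no higher from compound 3 to compound 4 (the limit leaves the size open) is expected to be small, and compound 4 is estimated at 10000 nM, within a range from 3000 nM to 30000 nM in this assay.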

Compound 4, half-maximal inhibitory concentration: 150 nM
Estimate against measurement, compound 4: 67-fold (1.82 log units) above; measured number below the stated range.
By their numbers in this assay, from the lowest: compound 4; then compounds 1 and 2 (each within the scatter of the next). At a limit, above all of these: compound 3.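

In this assay 4-fluoro-1H-indol-1-yl in place of 5-methoxy-1H-indol-1-yl gives an at least 66-fold lower number from compound 3 to compound 4 (1.82 log units; beyond the scatter) in one change, so an indole on this chain need not be weak. As far as these compounds go, the value of compound 3 is a limit of the assay, so the full size of that step stays open. The fluoroindole also improves on the other two groups, with a 5.7-fold lower number from compound 2 to compound 4 (0.75 log units; beyond the scatter) and a 3.7-fold lower number from compound 1 to compound 4 (0.57 log units; beyond the scatter) in the same read-out.

The substituent and its place on the indole change together here, and the compounds shown do not separate the two. From the compounds shown here alone, how an unsubstituted indole or a 4-chloro-1H-indol-1-yl group would read also stays open.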